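The compounds below may be only part of what the source reports. "The series", "measured", "known", "first", "only" and "open" are said of these compounds alone.

Working notes on the series.

Compound 1 `O=C(Nc1ccccc1C(F)(F)F)C1CCc2ccccc2N1` carries a free ring nitrogen; in a functional assay on MDA-MB-231 cells (Homo sapiens) for cytotoxicity, read by sulforhodamine B assay, with a stated time of 72 h (on this read-out higher numbers stand for weaker inhibition of growth and lower numbers for stronger inhibition of growth), compound 1 gives 45500 nM. Compound 2 `O=C(Nc1ccccc1C(F)(F)F)C1CCc2ccccc2N1C(=O)c1ccccc1` differs in one place, benzoyl in place of hydrogen on a nitrogen on an aromatic ring in a ring, and in this assay compound 2 gives 5290 nM. Within the data shown here, the step of an 8.6-fold lower number from compound 1 to compound 2 (0.93 log units; beyond the scatter) is the only measured step so far. On the numbers shown compound 2 stands lowest of the two, with compound 1 as its only neighbour.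

Compound 3 `O=C(Nc1ccccc1C(F)(F)F)C1CCc2ccccc2N1C(=O)c1ccccc1Cl` is not yet measured. It differs from compound 2 by chloro in place of hydrogen on an aromatic carbon; cut one bond further out, the change reads benzoyl to (2-chlorophenyl)carbonyl. Among the measured compounds shown here, no measured step touches this part of the molecule: the one step known changes the group on the ring nitrogen as a whole, not a substituent on the benzoyl ring, so it gives no direction for this change. Expectation therefore rests on compound 2 alone, with a step of a 1.2-fold lower number from compound 2 to compound 3 (0.07 log units; within the scatter) expected to stay within the scatter. Compound 3 is estimated at 4500 nM in this assay, in the range 1800 nM to 12000 nM.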

Compound 3, concentration for 50% growth inhibition: 2530 nM
The estimate for compound 3 lay 1.8-fold (0.25 log units) above the measured number; the measured number falls inside the stated range.
By their numbers in this assay, from the lowest: compound 3; then compound 2; then compound 1.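

Working from this assay, the new result shows that a substituent on the benzoyl ring itself can shift the read-out, which the earlier step, a change of the whole group on the ring nitrogen, could not show: chloro in place of hydrogen on an aromatic carbon, ortho to a large group, gives a 2.1-fold lower number from compound 2 to compound 3 (0.32 log units; beyond the scatter), a modest step but beyond the scatter. Counted from the free ring nitrogen, the (2-chlorophenyl)carbonyl group gives an 18-fold lower number from compound 1 to compound 3 (1.25 log units; beyond the scatter), a large step, against an 8.6-fold lower number from compound 1 to compound 2 (0.93 log units; beyond the scatter) for benzoyl, so in these three compounds the gain from acylating the nitrogen is extended by the chloro. The data offer no explanation for the effect of the chloro.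

The compounds shown leave open whether the step depends on chloro as such, or whether a methoxy group, an amine or a carboxylic acid at the same place would move the number in the same direction. They also leave open how chloro behaves at any other place on this ring, and whether the step holds when the trifluoromethyl group on the anilide ring gives way to a nitrile.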